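From benzyl to methyl in compound 3

The compounds below may be only part of what the source reports. "The series", "measured", "known", "first", "only" and "open" are said of these compounds alone.

Three compounds frame this step in an ADME assay on J774 cells (Mus musculus) for cytotoxicity; on this read-out higher numbers stand for an effect only at larger amounts of compound and lower numbers for an effect already at smaller amounts. Compound 1 `CCCCc1cc2c(=O)c(C#N)c[nH]c2cc1OCCOc1ccccc1` reads > 20000 nM, which is a limit of the assay and not a number. For compound 2 `CCCCc1cc2c(=O)c(C(C)=O)c[nH]c2cc1OCCOc1ccccc1` the entry is "not determined" (no result reported). Compound 3 `COC(=O)c1c[nH]c2ccc(OCc3ccccc3)cc2c1=O` stands at 7590 nM, and it is the only one of the three with a single number, so any comparison has to start from it.

Compound 4 `COC(=O)c1c[nH]c2ccc(OC)cc2c1=O` differs from compound 3 in one place: hydrogen in place of phenyl on a saturated chain carbon bound to an oxygen on an aromatic ring. In words, this is hydrogen in place of phenyl on a saturated chain carbon bound to an oxygen on an aromatic ring; cut one bond further out, it reads benzyl to methyl. Within the data shown here, no measured pair isolates this change, so the expectation is an extrapolation with a wide margin, anchored on compound 3 at 7590 nM. A moderate shift toward higher numbers in this assay is expected, meaning an effect only at larger amounts of compound. The expected change is a 2.4-fold higher number from compound 3 to compound 4 (0.38 log units; beyond the scatter). A report of compound 4 as a limit of the assay is about as likely as a single number. For compound 4 the estimate is 18000 nM, with an expected range from 7000 nM to 45000 nM.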

Compound 4, half-maximal effective concentration: 6180 nM
Estimate against measurement, compound 4: 2.9-fold (0.46 log units) above; measured number below the stated range.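

In this assay, the change from benzyl to methyl gives a 1.2-fold lower number from compound 3 to compound 4 (0.09 log units; within the scatter), so compound 3 and compound 4 stand within the scatter of each other. Among these compounds, this is the first pair that isolates one place, and it shows that, for this pair, losing the phenyl on a saturated chain carbon bound to an oxygen on an aromatic ring makes no difference that can be told from repeat scatter on this read-out. Both compounds give single numbers, whereas compound 1 carries a limit of the assay and not a number, so it sets no size for any step, and it differs from them in more than one place: the limit of > 20000 nM in this assay, at which 1 of the 4 values shown sits.

As far as these compounds go, the pair covers only the two ends of this change, so a longer chain, an amine or a carboxylic acid in place of the phenyl remains open at this position. Also open, from the compounds shown here alone, is whether the same change would behave alike on the core of compound 1, whose butyl-bearing scaffold offers no single-number reference in this assay.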